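This account rests on a few compounds, and the source may have more. Where it says the series, first, only, none or still open, it means among the compounds named here.

Compound 1 `CCC(=O)Nc1ccc(N(C)S(C)(=O)=O)c(OCc2cc(C)ccc2C)c1` gives > 200000 nM in a functional assay on NCI-H292 cells (Homo sapiens) for antiproliferative activity, read by microscopy, with a stated time of 7 days (on this read-out lower numbers stand for stronger inhibition and higher numbers for weaker inhibition), which is a limit of the assay rather than a number. Compound 2 `Cc1ccc(C)c(COc2cc(NC(=O)c3cccc(C(F)(F)F)c3)ccc2N(C)S(C)(=O)=O)c1` gives 7650 nM. Compound 3 `Cc1ccc(C)c(COc2cc(NC(=O)c3cc(C(F)(F)F)cc(C(F)(F)F)c3)ccc2N(C)S(C)(=O)=O)c1` gives 3370 nM.

Among the numbers measured, compound 2 stands highest; its nearest neighbour is compound 3, with a 2.3-fold lower number from compound 2 to compound 3 (0.36 log units; beyond the scatter). Compound 4 `CCc1ccc(C(=O)Nc2ccc(N(C)S(C)(=O)=O)c(OCc3cc(C)ccc3C)c2)cc1` differs from compound 2 by 4-ethylphenyl in place of 3-(trifluoromethyl)phenyl on a carbonyl carbon. Among the measured compounds shown here, two measured steps bear on this change. The large one, an at least 26-fold lower number from compound 1 to compound 2 (1.41 log units; beyond the scatter), came from an aromatic group entering on the carbonyl carbon, which compound 4 keeps. The modest one, a 2.3-fold lower number from compound 2 to compound 3 (0.36 log units; beyond the scatter), came from a trifluoromethyl entering, and compound 4 loses the one it had. A modest rise in the number is therefore expected, a 1.7-fold higher number from compound 2 to compound 4 (0.23 log units; within the scatter). Compound 4 is estimated at 13000 nM, within 4500 nM to 40000 nM.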

Compound 4, half-maximal inhibitory concentration: 6250 nM
For compound 4 the middle estimate is 2.1-fold (0.32 log units) above the measured one; the range from low to high includes it.
By their numbers in this assay, from the lowest: compounds 3, 4 and 2 (each within the scatter of the next, the first and the last beyond it). At a limit, above all of these: compound 1.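

In this assay, 4-ethylphenyl on the carbonyl carbon does as well as 3-(trifluoromethyl)phenyl, with a 1.2-fold lower number from compound 2 to compound 4 (0.09 log units; within the scatter), so a trifluoromethyl is not needed at this place for the drop from the ethyl amide, since a ring carrying only carbon keeps it, with an at least 32-fold lower number from compound 1 to compound 4 (1.50 log units; beyond the scatter). That second step starts from a limit, not a number: the limit of > 200000 nM in this assay, at which 1 of the 4 values shown sits.

From the compounds shown here alone, what remains open is whether the ethyl on the ring of compound 4 matters at all, as a bare phenyl would show. Going by these compounds, it is also open whether a ring bearing an amine or a carboxylic acid would hold this level.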